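Amide series on the shared core: the step to compound 3

This account rests on a few compounds, and the source may have more. Where it says the series, first, only, none or still open, it means among the compounds named here.

Among the measured compounds shown here, in a functional assay on HCT-116 cells (Homo sapiens) for antiproliferative activity, read by resazurin assay, with a stated time of 5 days (on this read-out higher numbers stand for weaker inhibition and lower numbers for stronger inhibition), two amides of the shared core have numbers so far. Compound 1 `Cc1ccc(C(=O)NCc2ccc3cc(C(=O)NO)sc3c2F)s1` gives 120 nM and compound 2 `Cc1ncoc1C(=O)NCc1ccc2cc(C(=O)NO)sc2c1F` gives 210 nM on the same read-out. These two values lie within the scatter of each other, so compound 2 stands level with compound 1 on the numbers shown.

The change to compound 3 `O=C(NCc1ccc2cc(C(=O)NO)sc2c1F)c1ccco1` is furan-2-yl in place of 4-methyl-1,3-oxazol-5-yl on a carbonyl carbon with furan-2-yl in place of 4-methyl-1,3-oxazol-5-yl on a carbonyl carbon. For the measured compounds named here, only one measured step bears on it, namely a 1.8-fold higher number from compound 1 to compound 2 (0.24 log units; within the scatter) at that same carbonyl carbon, which also exchanged one group for another and stayed within the scatter. One step is thin evidence, yet it gives no ground for expecting a large move. No step beyond the scatter is therefore expected in this assay and no firm direction can be claimed. The expected step is a 1.3-fold lower number from compound 2 to compound 3 (0.12 log units; within the scatter) and it would remain within the scatter. For compound 3 the estimated value is 160 nM and the expected range runs from 70 nM to 380 nM on this evidence.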

Compound 3, half-maximal inhibitory concentration: 90 nM
Beside the measured number, compound 3's estimate is 1.8-fold (0.25 log units) above it; the measured number falls inside the stated range.
By their numbers in this assay, from the lowest: compounds 3, 1 and 2 (each within the scatter of the next, the first and the last beyond it).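

Among the compounds shown here, at the carbonyl carbon whose other neighbour is the amide-type nitrogen, this assay now shows a first step beyond the scatter: furan-2-yl in place of 4-methyl-1,3-oxazol-5-yl gives a 2.3-fold lower number from compound 2 to compound 3 (0.37 log units; beyond the scatter), a modest change. Furan-2-yl in place of 5-methylthiophen-2-yl gives a 1.3-fold lower number from compound 1 to compound 3 (0.12 log units; within the scatter), so compound 3 stands level with compound 1 and the only separation among the three amides lies between compound 2 and compound 3. Nothing available on these compounds accounts for that separation.

As far as these compounds go, the step from compound 2 to compound 3 removes the methyl group and the ring nitrogen together, so the share of each in the change stays open. Also open is how this assay would read with a phenyl ring, a pyridine ring or a piperidine ring on this carbonyl carbon, since all three groups shown are five-membered aromatic rings.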